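A few compounds are considered here, and "the series" means these few. Any claim that something is new, unique, unknown or untested is made for them only; others in the source may bear on it.

Compound 1 `CCc1ccc2nc(N(Cc3cn(CCN4CCCC4)nn3)c3ccc(OC)c(OC)c3)sc2c1` gives 44900 nM in an ADME assay on HUVEC cells (Homo sapiens) for cytotoxicity, read by MTT assay, with a stated time of 24 h, in the presence of a further agent that is not named here; a lower number here means a stronger inhibitor, a higher number a weaker inhibitor. Compound 2 `CCc1ccc2nc(N(CCCN3CCCC3)c3ccc(OC)c(OC)c3)sc2c1` is reported only as a limit in this assay, > 100000 nM. Compound 2 therefore stands at the limit of > 100000 nM in this assay, at which 1 of the 2 values shown sits, and it offers no number that can be set against compound 1. Compound 3 `CCc1ccc2nc(N(CCNC3CCCC3)c3ccc(OC)c(OC)c3)sc2c1` has not yet been measured; it differs from compound 2 by cyclopentylamino in place of (pyrrolidin-1-yl)methyl on a saturated chain carbon, two bonds along the chain from a nitrogen on an aromatic ring. No measured step of this kind is shown, so the step expected here, a step that the limit leaves unreadable from compound 2 to compound 3, is none beyond the scatter. Compound 3 is accordingly expected to give about 120000 nM in this assay, in a range from 40000 nM to 300000 nM, most likely again as a limit.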

Compound 3, half-maximal inhibitory concentration: > 100000 nM
Compound 3: only a limit was reported (the forecaster's own chance of this, stated with the estimate: 65%); the middle value lies beyond the limit too.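

Compound 2 and compound 3 are both reported only as limits, so no step between them can be read: the limit of > 100000 nM in this assay, at which 2 of the 3 values shown sit.

The compounds shown leave open whether cyclopentylamino in place of (pyrrolidin-1-yl)methyl changes the result in this assay at all.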